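The compounds below may be only part of what the source reports. "The series", "measured", "known", "first", "only" and "open" are said of these compounds alone.

Measured in an assay on HEK293 cells for inhibition of transient receptor potential cation channel subfamily M member 8 (Homo sapiens), read by FLIPR, with stated times of 5 min and 3 min; on this read-out lower numbers stand for stronger inhibition and higher numbers for weaker inhibition:
compound 1 `CCOC(=O)c1cnc(-c2ccccc2)s1`: > 100000 nM
compound 2 `CCON(C)C(=O)c1sc(-c2ccccc2O)nc1O`: 1500 nM
compound 3 `CCOC(=O)Cc1sc(-c2ccccc2)nc1O`: 950 nM

The value of compound 1 is a limit of the assay and not a number (the limit of > 100000 nM in this assay, at which 1 of the 3 values shown sits). Compound 3 and compound 2 lie within the usual scatter of each other, so neither can be called the stronger inhibitor; compound 3 simply holds the lower of the two numbers shown. Compound 4 `O=C(O)c1sc(-c2ccccc2)nc1O` differs from compound 3 in one place: carboxy in place of (ethoxycarbonyl)methyl on an aromatic carbon. Among the compounds with values here, no pair of measured compounds differs in just this way, so no measured step shows what this change does. A free carboxy replacing the ester has no precedent among these compounds, and a moderate weakening is expected rather than no change. For compound 4 the estimate is 5000 nM, with a range from 1000 nM to 30000 nM. The expected step from compound 3 to compound 4 is a 5.3-fold higher number from compound 3 to compound 4 (0.72 log units; beyond the scatter).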

Compound 4, half-maximal inhibitory concentration: > 100000 nM
Compound 4 ended at the assay's limit; the forecaster's own chance of this, stated with the estimate: 20%; middle value at least 20-fold (1.30 log units) from the limit.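

At the aromatic carbon next to the ring sulfur, the activity of compound 3 does not survive this exchange: carboxy in place of (ethoxycarbonyl)methyl gives an at least 100-fold higher number from compound 3 to compound 4 (2.02 log units; beyond the scatter) in this assay. Within the data shown here, this is the first step at this position, and it shows that the group placed here can decide whether any inhibition is seen. Compound 4 stands at a limit of the assay and not at a number, so the true size of the loss stays unknown: the limit of > 100000 nM in this assay, at which 2 of the 4 values shown sit.

The compounds shown leave open how a carboxymethyl or an aminomethyl group would read at this position. The effect of the shorter group therefore cannot be separated from that of the free carboxy.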